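From 2-fluorobenzyl to 1-phenylethyl on the sulfonyl sulfur

A few compounds are considered here, and "the series" means these few. Any claim that something is new, unique, unknown or untested is made for them only; others in the source may bear on it.

Of the compounds shown here, two have been measured so far in a functional assay (Platelet, plasma) for inhibition, with Homo sapiens as the target; on this read-out higher numbers stand for weaker inhibition and lower numbers for stronger inhibition. Compound 1 (`N#Cc1cc2c(nc1N1CCC(C(=O)NS(=O)(=O)Cc3cc(Cl)cc(Cl)c3)CC1)COC2=O`) gives 30500 nM, and compound 2 (`N#Cc1cc2c(nc1N1CCC(C(=O)NS(=O)(=O)Cc3ccccc3F)CC1)COC2=O`) gives 23700 nM. These two values lie within the scatter of each other, so compound 2 stands level with compound 1 on the numbers available.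

The next compound, compound 3 (`CC(c1ccccc1)S(=O)(=O)NC(=O)C1CCN(c2nc3c(cc2C#N)C(=O)OC3)CC1`), has not yet been measured. It shares the core of compound 2, with 1-phenylethyl in place of 2-fluorobenzyl on a sulfonyl sulfur.

Within the data shown here, only one measured step bears on this change, as it also alters the group carried by the sulfonyl sulfur: a 1.3-fold lower number from compound 1 to compound 2 (0.11 log units; within the scatter). Among the measured compounds shown here, that single step is thin evidence, and no measured compound carries 1-phenylethyl. It nevertheless offers no ground for expecting a shift beyond the scatter in this assay, and no direction can be assigned.

The expected step is a 1.1-fold higher number from compound 2 to compound 3 (0.02 log units; within the scatter), which amounts to no real change. The estimated value for compound 3 is 25000 nM, with an expected range of 11000 nM to 55000 nM.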

Compound 3, half-maximal inhibitory concentration: 4160 nM
Beside the measured number, compound 3's estimate is 6.0-fold (0.78 log units) above it; the measured number lies below the stated range.
By their numbers in this assay, from the lowest: compound 3; then compounds 2 and 1 (each within the scatter of the next).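

In this assay the group on the sulfonyl sulfur can move the number beyond the scatter, which the step between compound 1 and compound 2 did not show: 1-phenylethyl in place of 2-fluorobenzyl gives a 5.7-fold lower number from compound 2 to compound 3 (0.76 log units; beyond the scatter) and 1-phenylethyl in place of 3,5-dichlorobenzyl gives a 7.3-fold lower number from compound 1 to compound 3 (0.87 log units; beyond the scatter) on the same read-out. Both steps run in the same direction and end at compound 3, which has the lowest number of the three, while the two halogen-bearing benzyl groups of compound 1 and compound 2 remain within the scatter of each other. No measured evidence accounts for this step.

1-phenylethyl differs from both benzyl groups in two ways at once, in its chain and in carrying no chlorine or fluorine, so the compounds shown do not separate these two changes. Plain benzyl, 2-phenylethyl and 2-phenylpropan-2-yl on the sulfonyl sulfur remain open, as do the separate mirror-image forms of 1-phenylethyl.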